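Changing the Ring on the Sulfonyl Sulfur of Compound 2

A few compounds are considered here, and "the series" means these few. Any claim that something is new, unique, unknown or untested is made for them only; others in the source may bear on it.

For the measured compounds named here, compound 2 `CCN(Cc1ccccc1)C(=O)C1CCN(S(=O)(=O)c2ccc3occc3c2)CC1` has the higher of the two numbers measured so far in a functional assay on CHO cells for positive allosteric modulation of muscarinic acetylcholine receptor M5 (Homo sapiens), read by calcium flux (a higher number here means a larger maximal response, a lower number a smaller maximal response), where compound 2 gives 80%. Its nearest neighbour is compound 1 `CCN(Cc1ccccc1)C(=O)C1CCN(S(=O)(=O)c2cccc(OC)c2)CC1`, which in this assay gives 77%; the step of a number 3 percentage points higher from compound 1 to compound 2 (within the scatter) came from placing 1-benzofuran-5-yl instead of 3-methoxyphenyl on the sulfonyl sulfur. Compound 3 `CCN(Cc1ccccc1)C(=O)C1CCN(S(=O)(=O)c2ccc3nsnc3c2)CC1` is not yet measured. Compared with compound 2 it carries a group of 9 heavy atoms (6 carbon, 2 nitrogen, 1 sulfur; one five-membered aromatic ring with 3 hetero atoms, one six-membered aromatic ring of carbon only) in place of a group of 9 heavy atoms (8 carbon, 1 oxygen; one five-membered aromatic ring with 1 hetero atom, one six-membered aromatic ring of carbon only), on a sulfonyl sulfur.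

Going by the values given here, the one measured step bears on this change, since it also exchanged the group on the sulfonyl sulfur, and it stayed within the scatter. With only that to go on, the step from compound 2 to compound 3 is expected to be about no change at the digits printed from compound 2 to compound 3 (within the scatter), that is, no change beyond the scatter. Compound 3 is therefore estimated at 80% in this assay, with a range from 60% to 100%.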

Compound 3, largest response reached (reported as percent of maximum), in percent of the reference or control that the assay uses: 81%
For compound 3 the middle estimate is 1 percentage points below the measured one; the measured number falls inside the stated range.
By their numbers in this assay, from the lowest: compounds 1, 2 and 3 (each within the scatter of the next).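

In this assay the group with a five-membered aromatic ring holding 3 hetero atoms, including nitrogen and sulfur, gives a number 1 percentage points higher from compound 2 to compound 3 (within the scatter) when it replaces 1-benzofuran-5-yl on the sulfonyl sulfur, and a number 4 percentage points higher from compound 1 to compound 3 (within the scatter) when it replaces 3-methoxyphenyl. This position has therefore now carried three different aromatic groups, one of them with 3 hydrogen-bond acceptors instead of 1, and compound 1, compound 2 and compound 3 cannot be told apart by their numbers. No measurement is available to explain this result.

On these data alone, whether a non-aromatic group such as cyclohexyl or a short chain such as methyl on the sulfonyl sulfur would give a similar response remains open. The ethyl and benzyl groups of the shared core are the same throughout, so the effect of a longer chain in place of ethyl is open too.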